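Alkoxy in place of methyl on the carboxamide ring

The source may report more compounds than this note shows. Statements on the series, on what has been measured and on what is new or still open speak of the compounds shown alone.

Measured so far in an assay on cells for inhibition of MAP kinase-interacting serine/threonine-protein kinase 1 (Homo sapiens), read by mobility shift assay, with stated times of 10 min and 60 min, in the presence of a further agent that is not named here; on this read-out lower numbers stand for stronger inhibition and higher numbers for weaker inhibition:
compound 1, `Cc1cc(-c2cccnc2)ccc1C(N)=O`: 22000 nM
compound 2, `Nc1snnc1-c1ccc(C(F)(F)F)cc1`: 50000 nM
compound 3, `CC(C)Oc1cc(-c2cncc(-c3cnn(C)c3)c2)ccc1C(N)=O`: 400 nM

Compound 1 stands second highest of the three numbers. Its nearest neighbour is compound 2, whose number lies beyond the scatter above it; furthest away is compound 3, whose number is far lower, again well beyond the scatter. Compound 3 carries an isopropoxy group at the position where compound 1 carries a methyl, and in addition a further group on the pyridine, so the two values cannot be tied to a single change.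

Compound 4, `NC(=O)c1ccc(-c2cccnc2)cc1OC1CCCCC1`, is not yet measured. It differs from compound 1 by cyclohexyloxy in place of methyl on an aromatic carbon. The change thus places an alkoxy group ortho to the carbamoyl group, as in compound 3, while the pyridine is left as in compound 1.

Given that compound 3 gives 400 nM against 22000 nM for compound 1, a step towards a lower number is expected for compound 4, clearly beyond the scatter, though not the full distance to compound 3, as part of that gap may rest on the pyridine substituent. The expected step is a 7.3-fold lower number from compound 1 to compound 4 (0.87 log units; beyond the scatter). For compound 4 the estimate in this assay is 3000 nM, with a range from 700 nM to 12000 nM.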

Compound 4, half-maximal inhibitory concentration: 1500 nM
The estimate for compound 4 lay 2.0-fold (0.30 log units) above the measured number, and the stated range covers the measured number.
By their numbers in this assay, from the lowest: compound 3; then compound 4; then compound 1; then compound 2.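

In this assay, cyclohexyloxy in place of methyl on the aromatic carbon ortho to the carbamoyl group gives a 15-fold lower number from compound 1 to compound 4 (1.17 log units; beyond the scatter) and is a large step well beyond the scatter. Within the data shown here, this is the first change that can be tied to one place, since the earlier compounds differ from each other in more than one: the lower number comes with the alkoxy group alone, with the rest of the core of compound 1 untouched. The position therefore takes a far larger group than methyl, one with a six-membered non-aromatic ring, and the number still falls rather than rises; nothing at hand bears on the reason for this step.

The compounds shown do not separate the part played by the ether oxygen from that of the cyclohexyl ring, so a small methoxy, a carbon-linked cyclohexylmethyl and a nitrogen-linked cyclohexylamino group at this position remain open comparisons. Also open, as far as these compounds go, is whether the gain at this position adds to a change elsewhere on the core, such as the methylpyrazole carried by compound 3, as that group has not been seen together with cyclohexyloxy in these data.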